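This account rests on a few compounds, and the source may have more. Where it says the series, first, only, none or still open, it means among the compounds named here.

Measured so far in a functional assay on MDA-MB-231 cells (Homo sapiens) for antiproliferative activity, read by sulforhodamine B assay, with a stated time of 48 h; a higher number here means a weaker inhibitor, a lower number a stronger inhibitor:
- compound 1 `COc1cc(C(=O)/C=C\Nc2ccc(-c3nc4cc(OC)c(OC)c(OC)c4s3)cc2C)cc([N+](=O)[O-])c1OC`: 12800 nM
- compound 2 `COc1ccc2nc(-c3ccc(N/C=C\C(=O)c4cc(OC)c(OC)c(OC)c4)c(C)c3)sc2c1`: 17000 nM
- compound 3 `COc1ccc2nc(-c3ccc(N/C=C\C(=O)c4ccc(OC)c(O)c4)cc3)sc2c1`: 18900 nM

Compound 2, at 17000 nM, lies within the scatter of both compound 1 and compound 3, so the three values form one tight group. Within the data shown here, no measured pair differs in one place only, so the series offers no clean single-change step.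

The next compound is compound 4 `COc1ccc2nc(-c3ccc(N/C=C\C(=O)c4cc(OC)c(OC)c(OC)c4)cc3)sc2c1`, which has hydrogen in place of methyl on an aromatic carbon relative to compound 2: hydrogen in place of methyl on an aromatic carbon.

Among the measured compounds shown here, the only indirect evidence is compound 3, which also lacks this methyl and gives 18900 nM, but it differs from compound 2 elsewhere too. Compound 2 gives 17000 nM, within the scatter of that value. No step beyond the scatter is therefore expected in this assay. The expected change is a 1.1-fold lower number from compound 2 to compound 4 (0.05 log units; within the scatter). For compound 4 the estimated value is 15000 nM, with an expected range from 6000 nM to 35000 nM.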

Compound 4, half-maximal inhibitory concentration: 19600 nM
The estimate for compound 4 lay 1.3-fold (0.12 log units) below the measured number, within the range that was stated.
By their numbers in this assay, from the lowest: compounds 1, 2, 3 and 4 (each within the scatter of the next).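

Hydrogen in place of methyl on an aromatic carbon, ortho to a large group and meta to a 6-methoxy-1,3-benzothiazol-2-yl group, gives a 1.2-fold higher number from compound 2 to compound 4 (0.06 log units; within the scatter) in this assay. Among these compounds, this is the first comparison that isolates a single place, and it shows that this methyl can be exchanged for hydrogen with no step beyond the scatter, which compound 3 could not show on its own. No measurement is available that would explain this result.

As far as these compounds go, whether an ethyl, a methoxy or an amine at the same position would also stay within the scatter remains open. The parts of the other ring, including the nitro group of compound 1 and the hydroxyl of compound 3, are not isolated by any single-place step, so their separate contributions cannot be read.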